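The compounds below may be only part of what the source reports. "The series", "measured", "known", "first", "only" and "open" are said of these compounds alone.

Of the compounds shown here, three built on the core of compound 1 have been tested in a functional assay on the whole organism for inhibition, with Mus musculus as the target, with stated times of 30 min and 2 h, at a dose of 10 mg/kg by the intraperitoneal route; a higher number here means more inhibition at the dose given (going by the name of the read-out), a lower number less inhibition. Compound 1 `COc1ccccc1C(=O)NCc1ccc(CNS(=O)(=O)c2ccccc2)cc1` is recorded as "not active" (no number reported) in this assay, so no number stands behind it. Compound 3 `COc1ccccc1C(=O)NCc1ccc(CNS(=O)(=O)c2ccc(C)cc2)cc1` is likewise recorded as "not active" (no number reported) in this assay, again without a number. Compound 2 `Cc1ccc(S(=O)(=O)NCc2ccc(CNC(=O)c3ccc(Cl)cc3)cc2)cc1`, which carries a chlorine on the amide ring and a methyl on the sulfonamide ring, gives 50% in this assay. Compound 1 has no number. Nothing can be said about the size of any step between it and compound 2 or compound 3.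

Compound 4 `O=C(NCc1ccc(CNS(=O)(=O)c2ccccc2)cc1)c1ccccc1` differs from compound 1 in one place: hydrogen in place of methoxy on an aromatic carbon. Read one bond further out, a 2-methoxyphenyl becomes a phenyl. Going by the values given here, no measured pair shows this change on its own, and compound 1 itself gave no number, so the direction of the step cannot be read from the data; compound 2, the only compound with a number, differs on both outer rings. Compound 4 is therefore expected to give only a modest result, estimated at 20% in this assay, within a range from 0% to 50%, and it may well return no number at all, as compound 1 and compound 3 did.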

Compound 4, a percentage reported as inhibition, in the whole organism at one dose (the size of the read-out at that dose, not a potency): 62%
Compound 4: the middle estimate sits 42 percentage points below what was measured; measured number outside the range, above it.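

Compound 4 gives 62% in this assay but compound 1 has no number there, so no step can be read between compound 1 and compound 4. The compounds shown leave open how much inhibition changes when a methoxy group alone is exchanged for hydrogen on this core. No measurement shown offers an explanation for the result of compound 4.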